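Benzyl in Place of Butyl on an Ester

The source may hold more compounds than are shown below. What is called first, only, known or untested is meant among the compounds shown, and "the series" means these compounds.

Compound 1 `CCCCOC(=O)c1cccc(-c2cc(C(=O)Nc3ccncc3)ccc2CN)c1`: 5.5 nM
Compound 2 `NCc1ccc(C(=O)Nc2ccncc2F)cc1-c1cccc(C(=O)OCC2CCCCO2)c1`: 12 nM

In an assay on isolated protein for inhibition of Rho-associated protein kinase 2 (Homo sapiens), read by radiometric assay (on this read-out lower numbers stand for stronger inhibition and higher numbers for weaker inhibition), compound 1 gives 5.5 nM, the lower of the two numbers shown. In this assay compound 2 gives 12 nM, a gap beyond the usual scatter. Compound 3 `NCc1ccc(C(=O)Nc2ccncc2)cc1-c1cccc(C(=O)OCc2ccccc2)c1` differs from compound 1 by phenyl in place of propyl on a saturated chain carbon bound to an oxygen next to a carbonyl group. Going by the values given here, no pair of measured compounds shows this change, so its size is unknown; only a modest step, within the scatter or slightly weakening, is expected, as a 1.5-fold higher number from compound 1 to compound 3 (0.16 log units; within the scatter). Compound 3 is therefore estimated at 8 nM, with a range from 3 nM to 25 nM.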

Compound 3, half-maximal inhibitory concentration: 45 nM
Beside the measured number, compound 3's estimate is 5.6-fold (0.75 log units) below it; the measured number lies above the stated range.
By their numbers in this assay, from the lowest: compound 1; then compound 2; then compound 3.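

At this ester, benzyl in place of butyl is not a neutral exchange: this assay records an 8.2-fold higher number from compound 1 to compound 3 (0.91 log units; beyond the scatter) for this single change. The group on the saturated chain carbon bound to the oxygen therefore matters to inhibition, which compound 1 and compound 2 could not show, since they differ in more than one place. No measurement here explains the weaker inhibition. On these data alone, it remains open whether an ethyl ester, a phenethyl ester or a carboxylic acid at this place would keep the number low.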